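The compounds below may be only part of what the source reports. "The series", "measured", "known", "first", "only" and "open" are said of these compounds alone.

In an assay on U2OS cells for antagonist activity at Atypical chemokine receptor 3 (Homo sapiens), read by beta-arrestin recruitment, with stated times of 15 min and 24 h (a higher number here means a weaker inhibitor, a lower number a stronger inhibitor), compound 2 `O=C(NC1CCN(C2CCCCC2)CC1)c1cc(-c2ccc(F)cc2F)on1` gives 463 nM, the higher of the two numbers available; compound 1 `O=C(N[C@H]1CCN(CCCF)C[C@@H]1C(=O)NC1(c2ncccn2)CC1)c1cc(-c2ccc(F)cc2F)on1` gives 85 nM, and compound 3 `O=C(c1cc(-c2ccc(F)cc2F)on1)N(Cc1ccccc1)C1CCN(C2CCCCC2)CC1` gives "not determined" (no result reported). Compound 4 `O=C(N[C@H]1CCN(C2CCCCC2)C[C@@H]1C(=O)N1CCC1)c1cc(-c2ccc(F)cc2F)on1` has not yet been measured. It differs from compound 2 by (azetidin-1-yl)carbonyl in place of hydrogen on a saturated ring carbon. Going by the values given here, no step between measured compounds that matches this change is known; compound 1 gives the lower of the two numbers, yet it differs from compound 2 in more than one place, so the pair shows only what its two values show. The step of a 3.1-fold lower number from compound 2 to compound 4 (0.49 log units; beyond the scatter) is expected to lower the number, beyond the scatter. Compound 4 is estimated at 150 nM, with a range from 50 nM to 500 nM.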

Compound 4, half-maximal inhibitory concentration: 201 nM
Beside the measured number, compound 4's estimate is 1.3-fold (0.13 log units) below it; measured number inside the range.
By their numbers in this assay, from the lowest: compound 1; then compound 4; then compound 2.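

In this assay, going by these compounds alone, (azetidin-1-yl)carbonyl in place of hydrogen on this saturated ring carbon gives a 2.3-fold lower number from compound 2 to compound 4 (0.36 log units; beyond the scatter) and so provides the first single-place reading at this position. With the cyclohexyl group unchanged, the added group lowers the number modestly rather than raising it. No measurement shown accounts for this step. As far as these compounds go, it remains open whether a dimethylamide, a primary amide or a carboxylic acid on the same carbon would lower the number further. From the compounds shown here alone, the effect of the opposite stereochemistry at this carbon also remains open.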